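Bromo for Trifluoromethyl on the Benzyl Group of Compound 3

The source may hold more compounds than are shown below. What is called first, only, known or untested is meant among the compounds shown, and "the series" means these compounds.

compound 1 `CC1(Cc2cccc(/C(N)=N/O)c2)CC(S(=O)(=O)c2ccc(F)cc2)=C(c2ccc(/C(N)=N/O)cc2)O1`: 50200 nM
compound 2 `CC1(Cc2cccc(C(F)(F)F)c2)CC(S(=O)(=O)c2ccc(F)cc2)=C(c2ccc(/C(N)=N/O)cc2)O1`: 49800 nM
compound 3 `CC1(Cc2ccccc2C(F)(F)F)CC(S(=O)(=O)c2ccc(F)cc2)=C(c2ccc(/C(N)=N/O)cc2)O1`: 105000 nM

These three compounds were measured in an ADME assay on cells (Peritoneal macrophage, Mus musculus, strain Balb/c) for cytotoxicity, read by resazurin assay, with a stated time of 72 h; a lower number here means that less compound is tolerated, a higher number that more compound is tolerated. Compound 3 gives the highest of the three numbers, standing a 2.1-fold higher number from compound 1 to compound 3 (0.32 log units; beyond the scatter) and a 2.1-fold higher number from compound 2 to compound 3 (0.32 log units; beyond the scatter). Compound 4 `CC1(Cc2ccccc2Br)CC(S(=O)(=O)c2ccc(F)cc2)=C(c2ccc(/C(N)=N/O)cc2)O1` differs from compound 3 by bromo in place of trifluoromethyl on an aromatic carbon. Among the compounds with values here, no measured step exchanges these two groups directly. The step of a 1.0-fold lower number from compound 1 to compound 2 (0.00 log units; within the scatter) shows that a swap of one group for another on an aromatic carbon left the number within the scatter, while a 2.1-fold higher number from compound 2 to compound 3 (0.32 log units; beyond the scatter) gave only a modest gain. Compound 4 is therefore expected to show a 1.2-fold lower number from compound 3 to compound 4 (0.07 log units; within the scatter), a step within the scatter. Compound 4 is estimated at 90000 nM, with a range from 45000 nM to 180000 nM.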

Compound 4, half-maximal cytotoxic concentration: 109000 nM
Compound 4: the middle estimate sits 1.2-fold (0.08 log units) below what was measured; the measured number falls inside the stated range.
By their numbers in this assay, from the lowest: compounds 2 and 1 (each within the scatter of the next); then compounds 3 and 4 (each within the scatter of the next).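

In this assay, bromo in place of trifluoromethyl on this aromatic carbon, ortho to a large group, stays within the scatter (a 1.0-fold higher number from compound 3 to compound 4 (0.02 log units; within the scatter)), so a single bromine atom serves here as well as the larger trifluoromethyl. Within the data shown here, the higher number, earlier seen only with 2-(trifluoromethyl)phenyl, also comes with 2-bromophenyl, as the modest steps of a 2.2-fold higher number from compound 2 to compound 4 (0.34 log units; beyond the scatter) and a 2.2-fold higher number from compound 1 to compound 4 (0.34 log units; beyond the scatter) show. Nothing available explains this result. The compounds shown leave open whether an amine or a carboxylic acid on this aromatic carbon would keep the number equally high.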